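The compounds below may be only part of what the source reports. "The series", "measured", "known", "first", "only" and "open" are said of these compounds alone.

Measured in a functional assay on A-375 cells (Homo sapiens) for cytotoxicity, read by MTT assay, with a stated time of 72 h; a higher number here means a weaker inhibitor, a lower number a stronger inhibitor:
- compound 1 `O=C1c2c[n+]([O-])c3ccccc3c2C(=O)c2c1c1ccccc1n2Cc1cn([C@H]2O[C@H](CO)[C@@H](O)[C@H]2O)nn1`: 340 nM
- compound 2 `CN1CCN(CCCCn2c3c(c4ccccc42)C(=O)c2c[n+]([O-])c4ccccc4c2C3=O)CC1`: 30 nM
- compound 3 `O=C1c2c[n+]([O-])c3ccccc3c2C(=O)c2c1c1ccccc1n2CCCCN1CCNCC1`: 460 nM

Among these three numbers, compound 1 holds the second highest place. Its value lies within the scatter of the value of compound 3, while compound 2 gives a clearly lower number.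

The step now followed leads from compound 1 to compound 4 `CC1(C)OC[C@H](Cn2cc(Cn3c4c(c5ccccc53)C(=O)c3c[n+]([O-])c5ccccc5c3C4=O)nn2)O1`, with the shared core and the five-membered aromatic ring with 3 nitrogen left unchanged. On an aromatic nitrogen of that ring, (2,2-dimethyl-1,3-dioxolan-4-yl)methyl stands in place of 3,4-dihydroxy-5-(hydroxymethyl)oxolan-2-yl: (2,2-dimethyl-1,3-dioxolan-4-yl)methyl in place of 3,4-dihydroxy-5-(hydroxymethyl)oxolan-2-yl on an aromatic nitrogen.

Within the data shown here, only one measured step is available, a 15-fold higher number from compound 2 to compound 3 (1.19 log units; beyond the scatter). It is large, but it concerns hydrogen in place of methyl on an amine nitrogen in a ring, and neither compound 1 nor compound 4 carries that ring. Among the measured compounds shown here, it therefore shows only that a small change away from the core can move the number in this assay, and it gives no direct measure for this exchange. A modest shift towards a lower number is expected, though with little certainty.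

The expected change is a 2.0-fold lower number from compound 1 to compound 4 (0.30 log units; within the scatter). For compound 4 the estimated value is 170 nM, with an expected range from 45 nM to 600 nM.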

Compound 4, half-maximal inhibitory concentration: 180 nM
Beside the measured number, compound 4's estimate is 1.1-fold (0.02 log units) below it, and the stated range covers the measured number.
By their numbers in this assay, from the lowest: compound 2; then compounds 4, 1 and 3 (each within the scatter of the next, the first and the last beyond it).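

In this assay, among these compounds, the exchange on the aromatic nitrogen of the five-membered aromatic ring with 3 nitrogen gives a 1.9-fold lower number from compound 1 to compound 4 (0.28 log units; within the scatter), the first reading of any change at this position. Although 3,4-dihydroxy-5-(hydroxymethyl)oxolan-2-yl, with 3 hydrogen-bond donors, 4 hydrogen-bond acceptors and 4 defined stereocentres, gives way to (2,2-dimethyl-1,3-dioxolan-4-yl)methyl, with 0 hydrogen-bond donors, 2 hydrogen-bond acceptors and 1 defined stereocentre, the assay does not separate the two compounds, whereas the step at the amine nitrogen elsewhere in the series, a 15-fold higher number from compound 2 to compound 3 (1.19 log units; beyond the scatter), lies beyond the scatter. No measurement is available that would explain why this exchange leaves the number within the scatter.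

Because the two groups differ at once in their ring, their hydrogen-bond donors and acceptors and their stereocentres, the compounds shown cannot assign any part of the result to one of these features alone. Going by these compounds, it also remains open whether a carboxylic acid, a primary amine or a longer alkyl chain on the same aromatic nitrogen would stay within the scatter of these two compounds or move the number as far as the step at the amine nitrogen did.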